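The compounds below may be only part of what the source reports. "The series", "measured", "known", "first", "only" and "open" are said of these compounds alone.

In an ADME assay on cells (Homo sapiens) for activation (a higher number here means that more compound is tolerated, a lower number that less compound is tolerated), compound 1 `COc1ccc2c(OCC[C@@H]3NC(=O)N(C)CCCC/C=C\[C@@H]4C[C@@]4(C(=O)NS(=O)(=O)C4(C)CC4)NC3=O)cc(-c3nc(C(C)C)cs3)nc2c1F` gives 57100 nM, compound 2 `COc1ccc2c(OCC[C@@H]3NC(=O)N(C)CCCC/C=C\[C@@H]4C[C@@]4(C(=O)NS(=O)(=O)N(C)C)NC3=O)cc(-c3nc(C(C)C)cs3)nc2c1Cl` gives 47800 nM and compound 3 `CCC1(S(=O)(=O)NC(=O)[C@@]23C[C@H]2/C=C\CCCCN(C)C(=O)N[C@@H](CCOc2cc(-c4nc(C(C)C)cs4)nc4c(Cl)c(OC)ccc24)C(=O)N3)CC1` gives 49300 nM and these three numbers lie within the usual scatter of one another. Compound 1 therefore sits level with the other two. Compound 4 `COc1ccc2c(OCC[C@@H]3NC(=O)N(C)CCCC/C=C\[C@@H]4C[C@@]4(C(=O)NS(=O)(=O)C4(C)CC4)NC3=O)cc(-c3nc(C(C)C)cs3)nc2c1Cl` keeps all of compound 1 except one group on an aromatic carbon, ortho to a methoxy group, where chloro takes the place of fluoro (chloro in place of fluoro on an aromatic carbon).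

Going by the values given here, no measured pair isolates this swap, so the evidence is indirect. Among the compounds with values here, the one measured step, a 1.0-fold higher number from compound 2 to compound 3 (0.01 log units; within the scatter) and that swap of dimethylamino for 1-ethylcyclopropyl on a sulfonyl sulfur, concerns a different part of the molecule and left the number within the scatter. The closest measured relative is compound 3, which carries chloro and gives 49300 nM while differing from compound 4 only in the group on the sulfonyl sulfur. On this basis, no step beyond the scatter is expected in this assay, and no direction can be claimed with confidence (estimated step: a 1.1-fold lower number from compound 1 to compound 4 (0.06 log units; within the scatter)). Compound 4 is estimated at 50000 nM (expected range 32000 nM to 78000 nM).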

Compound 4, half-maximal cytotoxic concentration: 37400 nM
For compound 4 the middle estimate is 1.3-fold (0.13 log units) above the measured one; measured number inside the range.
By their numbers in this assay, from the lowest: compounds 4, 2, 3 and 1 (each within the scatter of the next).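

In this assay, going by these compounds alone, chloro in place of fluoro on this aromatic carbon, ortho to a methoxy group, can now be read directly (a 1.5-fold lower number from compound 1 to compound 4 (0.18 log units; within the scatter)), whereas the earlier compounds offered no matched pair for this swap. Compound 4 also links this position to the group on the sulfonyl sulfur. With chloro held constant, two more single changes stay within the scatter: hydrogen in place of methyl on a saturated chain carbon bound to a saturated ring carbon (a 1.3-fold lower number from compound 3 to compound 4 (0.12 log units; within the scatter)) and a change of the group on the sulfonyl sulfur from dimethylamino to 1-methylcyclopropyl (a 1.3-fold lower number from compound 2 to compound 4 (0.11 log units; within the scatter)). No measurement shown here offers an explanation for how closely these numbers agree.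

From the compounds shown here alone, only fluoro and chloro appear on this aromatic carbon, so it remains open whether hydrogen, bromo, a nitrile or an amine there would also stay within the scatter. The fluoro compound carries only 1-methylcyclopropyl on the sulfonyl sulfur, so the same swap remains unread alongside dimethylamino, 1-ethylcyclopropyl or a longer chain in that place.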